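The compounds below may be only part of what the source reports. "The series", "measured", "known", "first", "only" and "open" are said of these compounds alone.

In an ADME assay on Akata cells (Homo sapiens) for cytotoxicity, with a stated time of 7 days (on this read-out lower numbers stand for higher toxicity in this test and higher numbers for lower toxicity in this test), compound 1 (`C=CCOc1nc(N)nc2c1ncn2/C=C1/CC1(CO)CO`) gives > 20000 nM, which is a limit. Compound 2 (`CCOc1nc(N)nc2c1ncn2/C=C1/CC1(CO)CO`) gives > 20000 nM, which is also a limit. Compound 3 (`CCCNc1nc(N)nc2c1ncn2/C=C1/CC1(CO)CO`) gives > 24000 nM, again a limit, so it stands with no numerical value, as do the other two compounds. Compound 4 (`Nc1nc(NC2CCCC2)c2ncn(/C=C3/CC3(CO)CO)c2n1`) differs from compound 3 as follows: cyclopentyl in place of propyl on a nitrogen on an aromatic ring. Within the data shown here, two measured steps bear on this change at the same substituent: a step that the two limits leave unreadable from compound 2 to compound 3 and a step that the two limits leave unreadable from compound 1 to compound 3. Neither has a readable size, so no step beyond the scatter, in either direction, is expected in this assay. The expected step is an at least 1.0-fold lower number from compound 3 to compound 4 (0.03 log units; that floor lies within the scatter). For compound 4 the estimated value is 22000 nM, with an expected range from 10000 nM to 48000 nM.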

Compound 4, half-maximal cytotoxic concentration: > 20000 nM
Compound 4: only a limit was reported; the forecaster's own chance of this, stated with the estimate: 70%; the middle value lies beyond the limit too.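

Among these compounds, compound 4, like compound 1, compound 2 and compound 3, is reported only as a limit in this assay, so no step between them can be read. The compounds shown leave open whether any substituent at this aromatic carbon gives a numerical cytotoxic concentration.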